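This account rests on a few compounds, and the source may have more. Where it says the series, first, only, none or still open, it means among the compounds named here.

Working notes on the series. Three compounds have numbers in a functional assay on MCF7 cells (Homo sapiens) for cytotoxicity, read by MTT assay, with a stated time of 48 h; a higher number here means a weaker inhibitor, a lower number a stronger inhibitor. Compound 3 `CCCCCCCCCCCCCCNC(=O)[C@@H](NS(=O)(=O)c1ccc(C)cc1)[C@@H](C)O` gives 12900 nM, the lowest of the three numbers. Compound 1 `CCCCCCCCCCCCNC(=O)[C@@H](NS(=O)(=O)c1cccs1)[C@@H](C)O` gives 19100 nM, which lies within the scatter of compound 3, so no order between these two can be read. Compound 2 `CCCCCCCCCCCCCCNC(=O)[C@@H](NC(=O)c1ccco1)[C@@H](C)O` gives 105000 nM, the furthest from compound 3. For the measured compounds named here, the only step between compounds that differ in one place is an 8.1-fold lower number from compound 2 to compound 3 (0.91 log units; beyond the scatter), a (4-methylphenyl)sulfonyl in place of a (furan-2-yl)carbonyl on the amine nitrogen.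

Compound 4 `CCCCCCCCCCCCCCNC(=O)[C@@H](NS(=O)(=O)c1cccs1)[C@@H](C)O` has no number yet in this assay. It differs from compound 3 by thiophen-2-yl in place of 4-methylphenyl on a sulfonyl sulfur. Going by the values given here, no measured step isolates this change. Compound 1 carries the same thiophen-2-yl group on the sulfonyl sulfur together with a shorter chain; compound 1 and compound 3 sit within the scatter of each other, so the two differences taken together yield no step beyond the scatter. The step from compound 2 to compound 3 concerns the group on the amine nitrogen, not the group on the sulfonyl sulfur, and bears only loosely on this case. The expected step is a 1.2-fold higher number from compound 3 to compound 4 (0.07 log units; within the scatter), none beyond the scatter. Compound 4 is therefore estimated at 15000 nM, with a range from 6000 nM to 40000 nM.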

Compound 4, half-maximal inhibitory concentration: 18700 nM
The estimate for compound 4 lay 1.2-fold (0.10 log units) below the measured number; the measured number falls inside the stated range.
By their numbers in this assay, from the lowest: compounds 3, 4 and 1 (each within the scatter of the next); then compound 2.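

In this assay the group on the sulfonyl sulfur now has a step of its own: thiophen-2-yl in place of 4-methylphenyl gives a 1.4-fold higher number from compound 3 to compound 4 (0.16 log units; within the scatter) and so shows no effect that can be read at this position. Compound 4 also splits the two differences that compound 1 and compound 3 carried together, since ethyl in place of hydrogen on a saturated chain carbon gives a 1.0-fold lower number from compound 1 to compound 4 (0.01 log units; within the scatter) and neither single change reaches beyond the scatter. On the amine nitrogen, (thiophen-2-yl)sulfonyl in place of (furan-2-yl)carbonyl gives a 5.6-fold lower number from compound 2 to compound 4 (0.75 log units; beyond the scatter) and so the lower number relative to compound 2 now appears with two different sulfonyl groups, not with (4-methylphenyl)sulfonyl alone.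

The compounds shown do not separate the sulfonyl from the ring it carries, as none pairs furan-2-yl with a sulfonyl or thiophen-2-yl with a carbonyl. Also open, from the compounds shown here alone, is whether a carboxylic acid or an amine in place of the methyl of 4-methylphenyl, or a much shorter chain, would move the number beyond the scatter. No outside evidence bears on these results.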